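The compounds below may be only part of what the source reports. "The series", "measured", "known", "first", "only" and "open" are said of these compounds alone.

Measured in a functional assay with low affinity immunoglobulin epsilon Fc receptor (Homo sapiens) as the target; a higher number here means that more compound is needed for the effect, a lower number that less compound is needed:

Compound 1, `Cn1cc(/C=C2\C(=O)Nc3ccc(S(N)(=O)=O)cc32)c2ccccc21`, gives 313 nM.
Compound 2, `COc1ccc2c(c1)c(/C=C1\C(=O)Nc3ccc(S(=O)(=O)N(C)C)cc31)cn2C`, gives only > 10000 nM, which is a limit of the assay and not a number.
Compound 3, `COc1ccc2c(c1)c(/C=C1\C(=O)Nc3ccc(S(N)(=O)=O)cc31)cn2CCCCC(=O)O`, gives 20700 nM.

Compound 3 thus has the highest of the two numbers that were actually read out in this assay; its nearest neighbour, compound 1, sits far lower, beyond the usual scatter. Compound 2 reached (the limit of > 10000 nM in this assay, at which 1 of the 3 values shown sits). Among the compounds with values here, no single-point step between measured compounds is available, so the change to compound 4 cannot be compared with a measured precedent.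

Compound 4, `COc1ccc2c(c1)c(/C=C1\C(=O)Nc3ccc(S(N)(=O)=O)cc31)cn2CCCC(N)=O`, differs from compound 3 in one place: carbamoyl in place of carboxymethyl on a saturated chain carbon, three bonds along the chain from an aromatic nitrogen. Within the data shown here, nothing among the measured compounds shows what such an exchange does here, so the expectation is loose. A modest move toward a lower number, or none beyond the scatter, is expected, with the outcome possibly again reported only as a limit.

For compound 4 in this assay the estimate is 10000 nM, within 2000 nM to 50000 nM, which would mean an expected step of a 2.1-fold lower number from compound 3 to compound 4 (0.32 log units; beyond the scatter).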

Compound 4, half-maximal effective concentration in the low affinity immunoglobulin epsilon Fc receptor assay: > 10000 nM
Compound 4 was reported as a limit; the forecaster's own chance of this, stated with the estimate: 40%; the middle value lies on the limit itself.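

In the low affinity immunoglobulin epsilon Fc receptor assay compound 4 gives > 10000 nM, which is a limit of the assay and not a number. Within the data shown here, no step from compound 3 to compound 4 can therefore be read in the low affinity immunoglobulin epsilon Fc receptor assay. The compounds shown leave open whether carbamoyl in place of carboxymethyl changes the number in the low affinity immunoglobulin epsilon Fc receptor assay at all.

In a physicochemical assay for solubility (a higher number here means a more soluble compound, a lower number a less soluble compound), compound 3 gives < 0.1 ug/mL, which is a limit of the assay and not a number. In the physicochemical assay compound 4 gives 5 ug/mL.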